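Swapping the para group of compound 3 for a larger, donor-free chain

The source may report more compounds than this note shows. Statements on the series, on what has been measured and on what is new or still open speak of the compounds shown alone.

Measured compounds:
- compound 1, `C/C(=N\OCCSc1nnnn1C)c1ccc(Sc2cc(F)cc(C3CCOCC3)c2)cc1`: 120 nM
- compound 2, `C/C(=N\OCc1ccncc1)c1ccc(Sc2cc(F)cc(C3CCOCC3)c2)cc1`: 300 nM
- compound 3, `CN(C)/C(=N\O)c1ccc(Sc2cc(F)cc(C3CCOCC3)c2)cc1`: 280 nM

All three share the same core and were tested in a functional assay (blood) for inhibition, with Homo sapiens as the target; a higher number here means a weaker inhibitor, a lower number a stronger inhibitor. Compound 3 stands second highest of the three numbers; its value and that of compound 2 lie within the scatter of each other, while compound 1 sits beyond the scatter below it.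

Compound 4, `C/C(=N\OC(=O)C(C)(C)C)c1ccc(Sc2cc(F)cc(C3CCOCC3)c2)cc1`, is not yet measured. It differs from compound 3 in one place: a group of 10 heavy atoms (7 carbon, 1 nitrogen, 2 oxygen; no ring) in place of a group of 6 heavy atoms (3 carbon, 2 nitrogen, 1 oxygen; no ring), on an aromatic carbon.

Among the measured compounds shown here, no measured step covers this exact exchange. For the measured compounds named here, the only step between measured compounds, a 2.5-fold higher number from compound 1 to compound 2 (0.40 log units; beyond the scatter), changed a group at the same position and moved the number by a modest amount, and all three measured values fall within a narrow band. Taken together, they suggest that groups of varied size at this position keep the number in the same region, so for compound 4 a change of a 1.4-fold lower number from compound 3 to compound 4 (0.15 log units; within the scatter) is expected, with no strong lean in either direction.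

Compound 4 is therefore estimated at 200 nM, within a range of 80 nM to 600 nM.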

Compound 4, half-maximal inhibitory concentration: 40 nM
For compound 4 the middle estimate is 5.0-fold (0.70 log units) above the measured one, outside the stated range (below it).
By their numbers in this assay, from the lowest: compound 4; then compound 1; then compounds 3 and 2 (each within the scatter of the next).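

In this assay, the three earlier values sat close together, which made this position look forgiving, yet the new group gives a 7.0-fold lower number from compound 3 to compound 4 (0.85 log units; beyond the scatter) and shows that the choice of group here can matter a good deal. The same holds among the compounds that keep the shared methyl-bearing carbon and vary only the group on the oxygen: (tert-butyl)carbonyl in place of (pyridin-4-yl)methyl gives a 7.5-fold lower number from compound 2 to compound 4 (0.88 log units; beyond the scatter), and (tert-butyl)carbonyl in place of 2-((1-methyl-1H-tetrazol-5-yl)sulfanyl)ethyl gives a 3.0-fold lower number from compound 1 to compound 4 (0.48 log units; beyond the scatter), so compound 4 is the strongest inhibitor of the four. Nothing in the available data bears on the reason for this gain.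

Among the compounds shown here, only one group with a carbonyl on this oxygen appears here, so it remains open whether a smaller acetyl group or a ring-bearing benzoyl group would give a similar number. A plain tert-butyl group on the same oxygen, with no carbonyl, would help separate the part played by the carbonyl from that of the branched carbon chain.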